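The compounds below may be only part of what the source reports. "The series", "measured", "known", "first", "only" and "open" are said of these compounds alone.

In a functional assay on HCT-116 cells (Homo sapiens) for inhibition, read by MTT assay, with a stated time of 72 h (a higher number here means a weaker inhibitor of growth, a lower number a stronger inhibitor of growth), compound 1 `O=C(/C=C/c1ccncc1-c1ccc2[nH]ccc2c1)N1CCOCC1` offers no number to start from: its entry reads "not determined" (no result reported) and gives no place on the scale. Compound 3 `O=C(O)COc1ccncc1-c1ccc2ccccc2c1` is no help either, with the entry "not determined" (no result reported) in the same readout. Only compound 2 `CNC(=O)/C=C/c1ccncc1-c1ccc2cc[nH]c2c1` gives a figure, at 10400 nM as the one measured anchor.

Compound 4 `CCOC(=O)/C=C/c1ccncc1-c1ccc2[nH]ccc2c1` keeps the core of compound 1 and changes one group (ethoxy in place of morpholin-4-yl on a carbonyl carbon). Ethoxy takes the place of morpholin-4-yl on a carbonyl carbon, so (morpholin-4-yl)carbonyl becomes ethoxycarbonyl.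

Among the measured compounds shown here, no measured pair shows what such a swap does, so the step in this assay can only be expected, not read off. A small move toward stronger inhibition of growth is expected, not clearly beyond the usual scatter. For the measured compounds named here, the expectation leans on compound 2 and its 10400 nM as the only guide to the likely range. For compound 4 the estimated value is 8000 nM with an expected range from 2500 nM to 25000 nM in this readout.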

Compound 4, concentration for 50% growth inhibition: 4830 nM
Compound 4: the middle estimate sits 1.7-fold (0.22 log units) above what was measured; low and high end bracket the measured number.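

No step can be read from compound 4 to compound 1 in this assay, since compound 1 at "not determined" (no result reported) gives no number to compare. From the compounds shown here alone, what replacing morpholin-4-yl with ethoxy does to growth inhibition stays open. No further data here explain the result.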